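Shortening the ether side chain back to a piperidine

This account rests on a few compounds, and the source may have more. Where it says the series, first, only, none or still open, it means among the compounds named here.

Compound 1 `c1cc([C@H]2CC[C@]3(CC2)OOC2(O3)C3CC4CC(C3)CC2C4)ccc1OCC1CCNCC1` gives 12.5 ug/mL in a physicochemical assay for solubility, read by nephelometry, measured as kinetic solubility, with a stated time of 30 min; on this read-out higher numbers stand for higher solubility and lower numbers for lower solubility.
Compound 2 `CC(C)(CN)Oc1ccc([C@H]2CC[C@]3(CC2)OOC2(O3)C3CC4CC(C3)CC2C4)cc1` reaches only the limit > 100 ug/mL, not a number.
Compound 3 `O[C@H]1CC[C@H](NCCCOc2ccc([C@H]3CC[C@]4(CC3)OOC3(O4)C4CC5CC(C4)CC3C5)cc2)CC1` likewise reaches only the limit > 100 ug/mL.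

Compound 3 therefore sits at the limit of > 100 ug/mL in this assay, at which 2 of the 3 values shown sit, the top of the three, with no exact figure. Compound 4 `c1cc([C@H]2CC[C@]3(CC2)OOC2(O3)C3CC4CC(C3)CC2C4)ccc1OC1CCNCC1` differs from compound 3 by piperidin-4-yl in place of 3-((4-hydroxycyclohexyl)amino)propyl on an oxygen on an aromatic ring. Among the measured compounds shown here, the group entering closely resembles the one carried by compound 1, so the step that bears on this change is an at least 8.0-fold higher number from compound 1 to compound 3 (0.90 log units; beyond the scatter), read in reverse. The step that the two limits leave unreadable from compound 2 to compound 3 adds nothing usable. Compound 4 is thus expected to show an at least 6.6-fold lower number from compound 3 to compound 4 (0.82 log units; beyond the scatter). Compound 4 is estimated at 15 ug/mL, with a range from 5 ug/mL to 45 ug/mL.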

Compound 4, solubility: > 100 ug/mL
Compound 4: no number, only a limit; the forecaster's own chance of this, stated with the estimate: 5%; at least 6.6-fold (0.82 log units) between middle value and limit.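

In this assay compound 4 gives > 100 ug/mL, which is a limit and not a number, so the long 3-((4-hydroxycyclohexyl)amino)propoxy chain is not required to reach this limit. Taking piperidin-4-yl in place of (piperidin-4-yl)methyl on the same oxygen gives an at least 8.0-fold higher number from compound 1 to compound 4 (0.90 log units; beyond the scatter). The steps to compound 4 from compound 2 and from compound 3 cannot be read: the limit of > 100 ug/mL in this assay, at which 3 of the 4 values shown sit.

Going by these compounds, how far compound 2, compound 3 and compound 4 lie beyond this limit stays open. So does whether another group on this oxygen, such as a morpholine or a carboxylic acid, would also reach it.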